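The compounds below may be only part of what the source reports. "The series", "measured", "known", "first", "only" and "open" are said of these compounds alone.

Measured in a functional assay on MCF7 cells (Homo sapiens) for inhibition, read by fluorescence, with a stated time of 72 h; a higher number here means a weaker inhibitor of growth, a lower number a stronger inhibitor of growth:
- compound 1 `CC(C)c1nccc2nn(-c3ccccc3)cc12` gives 98800 nM
- compound 2 `CC(C)c1nc(-c2ccccc2)cc2nn(-c3ccccc3)cc12` gives 91000 nM
- compound 3 `c1ccc(-n2cc3cnccc3n2)cc1` gives only a limit of this assay, > 100000 nM

The step of a 1.1-fold lower number from compound 1 to compound 2 (0.04 log units; within the scatter) is phenyl in place of hydrogen on an aromatic carbon. The step of an at least 1.0-fold higher number from compound 1 to compound 3 (0.00 log units; that floor lies within the scatter) is hydrogen in place of isopropyl on an aromatic carbon; compound 3 sits at the limit (the limit of > 100000 nM in this assay, at which 1 of the 3 values shown sits).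

Compound 4 `c1ccc(-c2cc3nn(-c4ccccc4)cc3cn2)cc1` is not yet measured. It differs from compound 3 by phenyl in place of hydrogen on an aromatic carbon. This is the same kind of change as from compound 1 to compound 2, on a core that differs by hydrogen in place of isopropyl on an aromatic carbon; the place in compound 1 is also meta to an isopropyl group, which compound 3 lacks. The step that the limit leaves unreadable from compound 3 to compound 4 is expected to stay within the scatter, because a 1.1-fold lower number from compound 1 to compound 2 (0.04 log units; within the scatter) was within it. Compound 4 is expected at 120000 nM (range 50000 nM to 400000 nM), most likely again reported only as a limit.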

Compound 4, concentration for 50% growth inhibition: 4800 nM
Compound 4: the middle estimate sits 25-fold (1.40 log units) above what was measured; the measured number lies below the stated range.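

Phenyl in place of hydrogen on an aromatic carbon gives an at least 20-fold lower number from compound 3 to compound 4 (1.31 log units; beyond the scatter) in this assay, and hydrogen in place of isopropyl gives a 19-fold lower number from compound 2 to compound 4 (1.28 log units; beyond the scatter), and the phenyl change does not carry over unchanged between the two cores: the same change on two cores in this assay, a 1.1-fold lower number (0.04 log units; within the scatter) from compound 1 to compound 2 and an at least 20-fold lower number (1.31 log units; beyond the scatter) from compound 3 to compound 4, at least 19-fold (1.28 log units) apart, beyond the scatter of two such steps. Compound 3 gives > 100000 nM, a limit of the assay and not a number. The result shows that the size of the phenyl step depends on the core in this one pair of cores, but it does not show why, nor how the step would run on any other core.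

Still open, as far as these compounds go, is whether a smaller chain such as methyl, in place of isopropyl, would leave the phenyl step as large as on the core of compound 3. Also open, from the compounds shown here alone, is whether a substituted phenyl, such as one carrying an amine or a carboxylic acid, would keep the value of compound 4.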